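From allyl to cyclobutylmethyl: an untested change

A few compounds are considered here, and "the series" means these few. Any claim that something is new, unique, unknown or untested is made for them only; others in the source may bear on it.

Measured in a functional assay on RAW264.7 cells (Mus musculus) for inhibition, read by Griess assay, with a stated time of 24 h; on this read-out lower numbers stand for stronger inhibition and higher numbers for weaker inhibition:
compound 1 `C=CCc1ccc(OCC=C(C)C)c(-c2ccc(OC)c(CC=C)c2)c1`: > 100000 nM (a limit)
compound 2 `CCCc1cc(-c2cc(Br)ccc2O)no1`: 63000 nM
compound 3 `C=CCn1cc(-c2cc(CCC)ccc2O)nn1`: > 50000 nM (a limit)

Only compound 2 gives a true number here. Compound 3 stands only at a limit, > 50000 nM, and compound 1 holds the other limit of the set.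

Compound 4 `CCCc1ccc(O)c(-c2cn(CC3CCC3)nn2)c1` departs from compound 3 by one change cyclobutyl in place of vinyl on a saturated chain carbon bound to an aromatic nitrogen, which also reads as allyl to cyclobutylmethyl.

Among the compounds with values here, no measured pair tests such a change, so no shift beyond the scatter is expected in this assay. The estimated move is a number no higher from compound 3 to compound 4 (the limit leaves the size open).

Compound 4 is estimated at 50000 nM, with an expected range of 15000 nM to 100000 nM.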

Compound 4, half-maximal inhibitory concentration: 33000 nM
The estimate for compound 4 lay 1.5-fold (0.18 log units) above the measured number; the range from low to high includes it.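

Swapping allyl for cyclobutylmethyl on the saturated chain carbon bound to an aromatic nitrogen gives an at least 1.5-fold lower number from compound 3 to compound 4 (0.18 log units; that floor lies within the scatter). Compound 3 stands only at a limit, > 50000 nM. In this assay, compound 4 gives this position its first true number, 33000 nM, showing that a ring of four carbons is tolerated here. The step's printed floor shows no gain beyond the scatter.

On these data alone, the real size of the step stays open. So does whether a longer chain or an amine in this place would give a lower number.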